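Swapping a Ring for a Short Chain on the Core

A few compounds are considered here, and "the series" means these few. Any claim that something is new, unique, unknown or untested is made for them only; others in the source may bear on it.

Measured compounds and their values:
- Compound 1, `OCCCNc1ncnc2[nH]cc(-c3cccc(Cl)c3)c12`: 2490 nM
- Compound 2, `CC(=O)NC1CCN(c2ncnc3[nH]cc(-c4cccc(Cl)c4)c23)CC1`: 1390 nM
- Compound 3, `CNC1CCN(c2ncnc3[nH]cc(-c4cccc(Cl)c4)c23)CC1`: 3540 nM

These three share a core and differ only in the group attached to it. In an assay on HEK293T cells for displacement of a labelled ligand from Leucine-rich repeat serine/threonine-protein kinase 2 (Homo sapiens), read by NanoBRET, with a stated time of 2 h (on this read-out higher numbers stand for weaker inhibition and lower numbers for stronger inhibition), compound 3 gives the highest of the three numbers. Its gap to compound 1 is small, a 1.4-fold higher number from compound 1 to compound 3 (0.15 log units; within the scatter), so those two cannot be told apart. Its gap to compound 2 is larger, a 2.5-fold higher number from compound 2 to compound 3 (0.41 log units; beyond the scatter), a modest step.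

Compound 4, `CC(CO)CN(C)c1ncnc2[nH]cc(-c3cccc(Cl)c3)c12`, is not yet measured. It differs from compound 3 in one place: a group of 7 heavy atoms (5 carbon, 1 nitrogen, 1 oxygen; no ring) in place of a group of 8 heavy atoms (6 carbon, 2 nitrogen; one six-membered non-aromatic ring with 1 hetero atom), on an aromatic carbon. The entering group has no ring and carries a hydroxyl, which makes it resemble the (3-hydroxypropyl)amino group of compound 1 more than the piperidine of compound 3. The step from compound 1 to compound 3 showed that exchanging an acyclic hydroxyl chain for the piperidine changed little, a 1.4-fold higher number from compound 1 to compound 3 (0.15 log units; within the scatter). On that basis no step beyond the scatter is expected in this assay for compound 4, and the estimated step is a 1.4-fold lower number from compound 3 to compound 4 (0.15 log units; within the scatter). Compound 4 is therefore expected to give about 2500 nM, within the range 900 nM to 7000 nM.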

Compound 4, half-maximal inhibitory concentration: 7140 nM
For compound 4 the middle estimate is 2.9-fold (0.46 log units) below the measured one, outside the stated range (above it).
By their numbers in this assay, from the lowest: compounds 2, 1, 3 and 4 (each within the scatter of the next, the first and the last beyond it).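

In this assay, a ring-free group carrying a hydroxyl on this aromatic carbon does not by itself fix the result: replacing (3-hydroxypropyl)amino with the group of 7 heavy atoms gives a 2.9-fold higher number from compound 1 to compound 4 (0.46 log units; beyond the scatter), a modest weakening. Replacing 4-(methylamino)piperidin-1-yl with that same group gives a 2.0-fold higher number from compound 3 to compound 4 (0.30 log units; within the scatter), so here the loss of the ring cannot be told apart from no change. Nothing available explains the difference between the two ring-free groups.

From the compounds shown here alone, it remains open whether the hydroxyl itself counts, which a methoxy or a plain methyl at the end of the same chain could test. Also open, going by these compounds, is how a chain ending in a carboxylic acid or a primary amine would read at this position.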